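Halogen swap on the styryl aryl ring: cytotoxicity notes

The source may hold more compounds than are shown below. What is called first, only, known or untested is meant among the compounds shown, and "the series" means these compounds.

Four compounds share one core and differ only in the halogen on the six-membered aromatic ring of carbon only and in where it sits. Compound 1 `Cn1c([N+](=O)[O-])cnc1/C=C/c1cccc(Br)c1` carries bromo; in an ADME assay on HeLa cells (Homo sapiens) for cytotoxicity, read by resazurin assay, with a stated time of 2 days (a lower number here means a stronger inhibitor, a higher number a weaker inhibitor), compound 1 gives 87100 nM. Compound 3 `Cn1c([N+](=O)[O-])cnc1/C=C/c1cccc(Cl)c1` carries chloro at the same place, and in this assay compound 3 gives 30200 nM. The change from compound 1 to compound 3 is chloro in place of bromo on an aromatic carbon and it made a step of a 2.9-fold lower number from compound 1 to compound 3 (0.46 log units; beyond the scatter). Compound 2 `Cn1c([N+](=O)[O-])cnc1/C=C/c1ccc(Br)cc1` has the same atoms as compound 1 joined differently; the difference between the two cores is not broken down here. In this assay compound 2 gives 72400 nM. Compound 1 and compound 2 lie within the scatter of each other, while compound 3 gives the lowest number of the three.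

Compound 4 `Cn1c([N+](=O)[O-])cnc1/C=C/c1ccc(Cl)cc1` is not yet measured. It differs from compound 2 by chloro in place of bromo on an aromatic carbon. This is the same kind of change as from compound 1 to compound 3, not the same: there the place was meta to a large group, here it is para to a large group. With only one earlier case to go on, the step is expected to be of about the size of a 2.9-fold lower number from compound 1 to compound 3 (0.46 log units; beyond the scatter). The expected step in this assay is a 2.6-fold lower number from compound 2 to compound 4 (0.41 log units; beyond the scatter). Compound 4 is thus expected to give about 28000 nM in this assay, most likely between 12000 nM and 70000 nM.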

Compound 4, half-maximal inhibitory concentration: 91200 nM
The estimate for compound 4 lay 3.3-fold (0.51 log units) below the measured number; the measured number lies above the stated range.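

In this assay, chloro in place of bromo on an aromatic carbon gives a 1.3-fold higher number from compound 2 to compound 4 (0.10 log units; within the scatter), and this step does not match the one seen earlier for the same change on the other core: the same change on two cores in this assay, a 2.9-fold lower number (0.46 log units; beyond the scatter) from compound 1 to compound 3 and a 1.3-fold higher number (0.10 log units; within the scatter) from compound 2 to compound 4, 3.6-fold (0.56 log units) apart, beyond the scatter of two such steps

In this series, the step from the earlier pair therefore cannot be carried over as a fixed increment to the core of compound 2, and at the place para to a large group the chloro and bromo compounds lie within the scatter of each other. With one pair on each core, this shows only that the outcome of the swap depended on the core in these two cases; it does not show why the two steps differ, nor does it set a rule for any further core.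

The compounds shown leave open how another group on the same six-membered aromatic ring, such as fluoro, iodo, methoxy, an amine or a carboxylic acid, would behave on each of the two cores. They also leave open whether the lower number of compound 3 is particular to that one compound or would recur with other groups at the same place.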